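Swapping Amino for Ethyl on a Shared Core

The source may report more compounds than this note shows. Statements on the series, on what has been measured and on what is new or still open speak of the compounds shown alone.

Going by the values given here, compound 3 `COc1cc(-c2noc(-c3ccc(N)cc3)n2)cc(OC)c1OC` is the one member of this set with a measured number: in a functional assay on cells (Splenocyte, Mus musculus, strain BALB/c) for inhibition, read by scintillation counting and thymidine incorporation, with stated times of 48 h and 8 h (a lower number here means a stronger inhibitor, a higher number a weaker inhibitor), compound 3 gives 800 nM. Compound 1 `COc1ccc(OC)c(-c2nc(Cc3c[nH]c4ccccc34)no2)c1` reaches only the assay limit, > 50000 nM. Compound 2 `COc1cc(-c2noc(-c3ccccc3)n2)cc(OC)c1OC` likewise sits at the limit, > 50000 nM. Among the compounds with values here, the single measured step runs an at least 62-fold lower number from compound 2 to compound 3 (1.79 log units; beyond the scatter); because the limit of > 50000 nM in this assay, at which 2 of the 3 values shown sit, holds two of the three values, its true size stays open. Compound 4 `CCc1ccc(-c2nc(-c3cc(OC)c(OC)c(OC)c3)no2)cc1` differs from compound 3 by ethyl in place of amino on an aromatic carbon. Since this change removes the group whose arrival gave an at least 62-fold lower number from compound 2 to compound 3 (1.79 log units; beyond the scatter), a return toward weaker inhibition is expected, with a real chance of another limit. The expected value for compound 4 is 25000 nM, ranging from 3000 nM to 200000 nM, an estimated step of a 31-fold higher number from compound 3 to compound 4 (1.49 log units; beyond the scatter).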

Compound 4, half-maximal inhibitory concentration: > 50000 nM
Compound 4 was reported as a limit; the forecaster's own chance of this, stated with the estimate: 55%; at least 2.0-fold (0.30 log units) between middle value and limit.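

In this assay, ethyl in place of amino gives an at least 62-fold higher number from compound 3 to compound 4 (1.79 log units; beyond the scatter). So not just any group at this position on the aromatic ring brings the gain seen with amino: with ethyl there, compound 4 stays at a limit, as does compound 2, which carries hydrogen in that place. How compound 2 and compound 4 compare cannot be read, because both values are limits: the limit of > 50000 nM in this assay, at which 3 of the 4 values shown sit.

On these data alone, whether a hydroxyl or a methylamino group in that place would match compound 3 at 800 nM stays open. As far as these compounds go, the true size of the loss with ethyl also stays open.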